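A few compounds are considered here, and "the series" means these few. Any claim that something is new, unique, unknown or untested is made for them only; others in the source may bear on it.

Compound 2 `COc1cc(-c2nnc(SCc3cccc(Cl)c3)o2)ccc1O` gives, in a functional assay on cells (T-cell, Mus musculus, strain BALB/c) for inhibition, read by MTT assay, with stated times of 24 h and 72 h (on this read-out higher numbers stand for weaker inhibition and lower numbers for stronger inhibition), a value of 8290 nM. Its companion is compound 1 `COc1cc(-c2nnc(SCc3ccc(Cl)cc3)o2)ccc1O`, which in this assay gives 11100 nM. Among the compounds with values here, of the two numbers, compound 2 holds the lower one, yet the only step that joins them, a 1.3-fold lower number from compound 1 to compound 2 (0.13 log units; within the scatter), is too small to set the two apart, so neither compound can be called the stronger inhibitor on this evidence.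

Compound 3 `COc1cc(-c2nnc(SCc3ccccc3Cl)o2)ccc1O` has not yet been measured in this assay. It differs from compound 2 in a single respect: 2-chlorophenyl in place of 3-chlorophenyl on a saturated chain carbon bound to a sulfur. Within the data shown here, the only measured step that bears on such a change is the one from compound 1 to compound 2, where the chlorophenyl group was likewise rearranged and the number moved by a 1.3-fold lower number from compound 1 to compound 2 (0.13 log units; within the scatter). That precedent gives no sign that moving the chlorine around the phenyl ring shifts the number beyond the scatter, in either direction.

Compound 3 is therefore expected to give about 8500 nM in this assay, somewhere between 3500 nM and 21000 nM, which means an expected step of a 1.0-fold higher number from compound 2 to compound 3 (0.01 log units; within the scatter) from compound 2.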

Compound 3, half-maximal inhibitory concentration: 8430 nM
For compound 3 the middle estimate is 1.0-fold (0.00 log units) above the measured one; low and high end bracket the measured number.
By their numbers in this assay, from the lowest: compounds 2, 3 and 1 (each within the scatter of the next).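

Until now, only the swap between 4-chlorophenyl and 3-chlorophenyl had been read; the 2-chlorophenyl group on a saturated chain carbon bound to a sulfur now completes the set of chlorophenyl isomers. In this assay, the new group gives a 1.0-fold higher number from compound 2 to compound 3 (0.01 log units; within the scatter) and a 1.3-fold lower number from compound 1 to compound 3 (0.12 log units; within the scatter), so both steps stay within the scatter and compound 3 cannot be ranked against either of the other two compounds. Across these compounds, then, moving the chlorine around the phenyl ring produces no readable change in inhibition, and the evidence at hand offers no explanation for this flat result.

Since every compound shown carries a chlorophenyl group, they leave open whether the chlorine matters at all, and how a plain phenyl, a methoxy group, a carboxylic acid or an amine on that ring would compare. They also leave open what a longer chain between the sulfur and the ring would do, and how changes to the shared core would affect the number.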